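The source may report more compounds than this note shows. Statements on the series, on what has been measured and on what is new or still open speak of the compounds shown alone.

This account follows the step from compound 1 `CCOC(=O)/C=C/c1ccncc1-c1ccc2[nH]ccc2c1` to compound 4 `O=C(O)/C=C/c1ccncc1-c1ccc2[nH]ccc2c1`. In a functional assay on MDA-MB-231 cells (Homo sapiens) for inhibition, read by sulforhodamine B assay, with a stated time of 72 h (a higher number here means a weaker inhibitor of growth, a lower number a stronger inhibitor of growth), compound 1 gives > 10000 nM, which is a limit of the assay and not a number. Two further compounds stand alongside it. Compound 2 `NC(=O)/C=C/c1ccncc1-c1ccc2ccccc2c1` also gives only a limit, > 10000 nM. Compound 3 `NNC(=O)CCc1ccncc1-c1ccc2ccccc2c1` likewise gives only a limit, > 10000 nM. Within the data shown here, the one measured step, a step that the two limits leave unreadable from compound 2 to compound 3, sits between two limits and has no readable size. the limit of > 10000 nM in this assay, at which 3 of the 3 values shown sit, is thus all the evidence there is: every value shown sits at the limit. The change from compound 1 to compound 4 is hydrogen in place of ethyl on an oxygen next to a carbonyl group. Among the measured compounds shown here, no measured step bears on this change, and no value shown gives a number from which a direction could be read. Compound 1 is expected to pass its limit on to compound 4 without a readable step in this assay, a step that the limit leaves unreadable from compound 1 to compound 4. Compound 4 is estimated at 20000 nM, within 8000 nM to 100000 nM, and is most likely to be reported again only as a limit.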

Compound 4, concentration for 50% growth inhibition: > 10000 nM
Compound 4 was reported as a limit; the forecaster's own chance of this, stated with the estimate: 85%; the middle value lies beyond the limit too.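

The step from compound 1 to compound 4 cannot be read, as both values are limits and not numbers: the limit of > 10000 nM in this assay, at which 4 of the 4 values shown sit.

The compounds shown leave open whether hydroxy in place of ethoxy changes growth inhibition at all, and in which direction, since none gives a readable value in this assay.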